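Swapping a nitro for a chloro on a urea side chain

The source may hold more compounds than are shown below. What is called first, only, known or untested is meant among the compounds shown, and "the series" means these compounds.

Measured compounds:
- compound 1, `Cc1cc(NC(=O)Nc2cccc([N+](=O)[O-])c2)c2ccccc2n1`: > 25000 nM
- compound 2, `Cc1cc(NC(=O)Nc2ccc(OC(F)(F)F)cc2)c2ccccc2n1`: 14000 nM
- compound 3, `Cc1cc(NC(=O)Nc2ccc(Cl)cc2Cl)c2ccccc2n1`: 10000 nM

All three share one core and differ only in the groups on the outer aromatic ring of the urea. In an ADME assay on HEK293 cells (Homo sapiens) for cytotoxicity, with a stated time of 72 h (a lower number here means that less compound is needed, a higher number that more compound is needed for the effect), compound 1 gives > 25000 nM; this is a limit of the assay and not a measured number, so its true value is known only as a range (the limit of > 25000 nM in this assay, at which 1 of the 3 values shown sits). Compound 2, carrying a trifluoromethoxy group, gives 14000 nM in this assay, and compound 3, with two chloro groups, gives 10000 nM.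

The unmeasured compound 4, `Cc1cc(NC(=O)Nc2cccc(Cl)c2)c2ccccc2n1`, follows from compound 1 by one change: chloro in place of nitro on an aromatic carbon. Among the compounds with values here, no measured pair in this set shows a step of exactly this kind, so the expectation rests on the spread among compounds 1 to 3. Because compound 3 sits at 10000 nM with chloro groups on the same ring, a modest move toward a lower value is expected, an at least 1.5-fold lower number from compound 1 to compound 4 (0.19 log units; that floor lies within the scatter). For compound 4 the estimate in this assay is 16000 nM, with a range from 7000 nM to 30000 nM, and a real chance that only a limit is reported again.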

Compound 4, half-maximal effective concentration: 21000 nM
Compound 4: the middle estimate sits 1.3-fold (0.12 log units) below what was measured; the measured number falls inside the stated range.
By their numbers in this assay, from the lowest: compounds 3, 2 and 4 (each within the scatter of the next, the first and the last beyond it). At a limit, above all of these: compound 1.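

With chloro in place of nitro on the outer ring, compound 4 gives 21000 nM in this assay, so this position now has a measured number. Within the data shown here, this is the first single-place change in the set, and it is recorded as an at least 1.1-fold lower number from compound 1 to compound 4 (0.07 log units; that floor lies within the scatter). Compound 1 remains at a limit of the assay, so the floor of this step is known but its true size is not: the limit of > 25000 nM in this assay, at which 1 of the 4 values shown sits.

The compounds shown leave open how far the value would move with an amine, a methoxy group or a carboxylic acid in this same place. They also leave open whether chloro in place of nitro would give a similar step at another place on this ring.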